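Fused bicyclic amide variation and microsomal stability

The compounds below may be only part of what the source reports. "The series", "measured", "known", "first", "only" and "open" are said of these compounds alone.

The series keeps one amide-linked sulfonamide side chain and varies the fused bicyclic acid part. Among the measured compounds shown here, in an ADME assay on microsomes from liver (Homo sapiens) for metabolic stability, read by LC-MS, with a stated time of 30 min, tested at 1 uM (a higher number here means that more of the compound is left, a lower number that less of the compound is left), compound 1 `O=C(NCc1ccc(S(=O)(=O)N2CCCCC2)cc1)c1cc2cnccc2s1` gives 15% and compound 2 `O=C(NCc1ccc(S(=O)(=O)N2CCCCC2)cc1)c1cc2ccncc2[nH]1` gives 50%; the step of a number 35 percentage points higher from compound 1 to compound 2 (beyond the scatter) is the only measured step in this assay. On these data alone, compound 3 `O=C(NCc1ccc(S(=O)(=O)N2CCCCC2)cc1)c1ccn2ccnc2c1` gives "not determined" (no result reported) in this assay, so its standing on the numbers is unknown. Compound 4 `O=C(NCc1ccc(S(=O)(=O)N2CCCCC2)cc1)c1cc2ccncc2o1` differs from compound 3 by a group of 9 heavy atoms (7 carbon, 1 nitrogen, 1 oxygen; one five-membered aromatic ring with 1 hetero atom, one six-membered aromatic ring with 1 hetero atom) in place of a group of 9 heavy atoms (7 carbon, 2 nitrogen; one five-membered aromatic ring with 2 hetero atoms, one six-membered aromatic ring with 1 hetero atom), on a carbonyl carbon. For the measured compounds named here, no measured step bears on this particular exchange, and the single measured step concerns a different pair of bicycles, so the direction of change from compound 3 cannot be read from the data. Compound 4 is expected to give 30% in this assay, estimated between 10% and 60%.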

Compound 4, percent of the compound remaining: 56%
The estimate for compound 4 lay 26 percentage points below the measured number; measured number inside the range.
By their numbers in this assay, from the lowest: compound 1; then compounds 2 and 4 (each within the scatter of the next).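

In this assay, a number 6 percentage points higher from compound 2 to compound 4 (within the scatter) places the oxygen-containing bicycle on the carbonyl carbon level with the bicycle of compound 2, so this exchange leaves the read-out unresolved. a number 41 percentage points higher from compound 1 to compound 4 (beyond the scatter) is a second large step away from the sulfur-containing bicycle of compound 1, which now stands apart from both other measured bicycles. No evidence on hand gives a reason for these steps.

On these data alone, the standing of compound 3 stays unknown. Also open, as far as these compounds go, is how an amine or a carboxylic acid on the fused bicycle would read in this assay.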